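A few compounds are considered here, and "the series" means these few. Any claim that something is new, unique, unknown or untested is made for them only; others in the source may bear on it.

Working notes on the series.

Three compounds have been run in a functional assay on HCT-116 cells (Homo sapiens); a lower number here means a stronger inhibitor of growth, a higher number a weaker inhibitor of growth. Compound 1 `Oc1cc(-c2ccc(Cl)cc2)nc2ncccc12` gives 32400 nM in this assay. Compound 2 `COc1ccc(-c2cc(O)c3c(C)cc(C)nc3n2)cc1` gives 36300 nM in this assay, a value within the scatter of compound 1. Compound 3 `Cc1ccnc2nc(-c3ccc(Cl)cc3)cc(O)c12` gives 3720 nM in this assay, the lowest number of the three, and its steps to the other two lie beyond the scatter.

One single-point change is on record: hydrogen in place of methyl on an aromatic carbon, which raises the number, an 8.7-fold higher number from compound 3 to compound 1 (0.94 log units; beyond the scatter). The cores of compound 2 and compound 3 differ in more than one place, and that difference is not broken down here.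

Compound 4 `COc1ccc(-c2cc(O)c3ccc(C)nc3n2)cc1` is not yet measured. It is related to compound 2 by the same kind of change: hydrogen in place of methyl on an aromatic carbon. Going by the values given here, the surroundings are not identical, since in compound 2 the place is also meta to a methyl group (1 heavy atom), which has no counterpart in compound 3.

Against that single precedent, the step from compound 2 to compound 4 is expected to be of the same sign, a 3.3-fold higher number from compound 2 to compound 4 (0.52 log units; beyond the scatter), because an 8.7-fold higher number from compound 3 to compound 1 (0.94 log units; beyond the scatter) is the only guide available. Compound 4 is therefore estimated at 120000 nM in this assay, between 40000 nM and 400000 nM.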

Compound 4, concentration for 50% growth inhibition: > 100000 nM
Compound 4: a limit, no number; the forecaster's own chance of this, stated with the estimate: 35%; the middle value does not contradict the limit.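

In this assay compound 4 gives > 100000 nM, which is a limit of the assay and not a number. Hydrogen in place of methyl on the aromatic carbon gives an at least 2.7-fold higher number from compound 2 to compound 4 (0.44 log units; beyond the scatter), so this step has the same sign as the earlier one, and across these two pairs the direction of the change carries from one core to the other. This does not show that the size of the step carries over, and two pairs establish no rule for the series: the same change on two cores in this assay, an 8.7-fold higher number (0.94 log units; beyond the scatter) from compound 3 to compound 1 and an at least 2.7-fold higher number (0.44 log units; beyond the scatter) from compound 2 to compound 4; the limit leaves it open whether they differ

What an ethyl group or an amine would give in place of the methyl in this assay stays open, since the compounds shown compare only methyl and hydrogen at this place. Also open, as far as these compounds go, are the effect of changing the methyl group that remains in compound 4 and whether the direction holds on any further core.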